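From pyridin-3-yl to furan-2-yl on a carbonyl carbon

The source may hold more compounds than are shown below. What is called first, only, known or untested is meant among the compounds shown, and "the series" means these compounds.

Of the compounds shown here, three sharing one core have been tested in an ADME assay on HepG2 2.2.15 cells (Homo sapiens) for cytotoxicity, read by MTT assay (a lower number here means that less compound is tolerated, a higher number that more compound is tolerated), so far. Compound 1 (`CC(=O)c1ccc(OC(=O)/C=C/c2ccc(F)cc2)cc1`) gives > 3310000 nM as a limit of the assay. Compound 2 (`CC(=O)c1ccc(OC(=O)c2ccccc2)cc1`) gives > 3340000 nM as a limit of the assay too. Among the measured compounds shown here, compound 3 (`CC(=O)c1ccc(OC(=O)c2cccnc2)cc1`) gives 3010000 nM and this is the only actual number in the set.

The next compound to be read is compound 4 (`CC(=O)c1ccc(OC(=O)c2ccco2)cc1`), which has furan-2-yl in place of pyridin-3-yl on a carbonyl carbon. For the measured compounds named here, one measured step bears on this change, since it concerns the same place. Going by the values given here, no step beyond the scatter is expected here because an at least 1.1-fold lower number from compound 2 to compound 3 (0.04 log units; that floor lies within the scatter) is the only exchange at this place with a measured outcome. That single step is thin support, and it rests on a limit rather than on two numbers. The estimated step is a 1.0-fold lower number from compound 3 to compound 4 (0.00 log units; within the scatter) and no clear direction is expected. The reading may well come back as a limit, as it did for compound 1 and compound 2. For compound 4 the expected value is 3000000 nM with an estimated range from 1700000 nM to 4500000 nM in this assay if a number is reported.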

Compound 4, half-maximal cytotoxic concentration: > 4040000 nM
Compound 4 ended at the assay's limit (the forecaster's own chance of this, stated with the estimate: 50%); middle value at least 1.3-fold (0.12 log units) away from the limit.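

Compound 4 is read only as a limit: the limit of > 4040000 nM in this assay, at which 1 of the 4 values shown sits. Among the compounds shown here, this makes furan-2-yl the second group on the carbonyl carbon, after phenyl in compound 2, to give a limit in this assay, which leaves compound 3, with pyridin-3-yl, as the only one of the four compounds with an actual number. The exchange of a six-membered aromatic ring for a five-membered one gives an at least 1.3-fold higher number from compound 3 to compound 4 (0.12 log units; that floor lies within the scatter), so this floor does not separate the two compounds, though the true size of the step may be larger, and the step from compound 2 to compound 4 cannot be read.

With three of the four values being limits, the compounds shown leave open whether any group on this carbonyl carbon can shift the reading in this assay beyond the scatter, and in which direction. For the compounds shown here, also open is how a saturated amine such as piperidin-4-yl, a phenyl group carrying a carboxylic acid, or a longer alkyl chain at this place would read against compound 3, the one compound here that offers a number to compare with.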